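This account rests on a few compounds, and the source may have more. Where it says the series, first, only, none or still open, it means among the compounds named here.

Series notes. Compound 1 `CC(O)(CSc1cccc(C(F)(F)F)c1)C(=O)Nc1cccc(S(F)(F)(F)(F)F)c1` is the parent; in a functional assay on CWR22R cells (Homo sapiens) for antiproliferative activity, read by propidium iodide staining, with a stated time of 96 h (on this read-out higher numbers stand for weaker inhibition and lower numbers for stronger inhibition), compound 1 gives 12900 nM. Compound 2 `CC(O)(CSc1ccccc1C(F)(F)F)C(=O)Nc1cccc(S(F)(F)(F)(F)F)c1` differs from it by 2-(trifluoromethyl)phenyl in place of 3-(trifluoromethyl)phenyl on a sulfur, and in this assay compound 2 gives 13200 nM; the step is a 1.0-fold higher number from compound 1 to compound 2 (0.01 log units; within the scatter). Compound 3 `CC(O)(CS(=O)(=O)c1cccc(C(F)(F)F)c1)C(=O)Nc1cccc(S(F)(F)(F)(F)F)c1` carries a sulfonyl in place of the sulfur of compound 1; the difference between the two cores is not broken down here. In this assay compound 3 gives 24600 nM, and its gaps to compound 1 and compound 2 are within the usual scatter, so no order among the three is claimed.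

Compound 4 `CC(O)(CS(=O)(=O)c1ccccc1C(F)(F)F)C(=O)Nc1cccc(S(F)(F)(F)(F)F)c1` is not yet measured. It differs from compound 3 by 2-(trifluoromethyl)phenyl in place of 3-(trifluoromethyl)phenyl on a sulfonyl sulfur. This is the same kind of change as that between compound 1 and compound 2, though the place is not identical: there the group sits on a sulfur whose other neighbours are a saturated chain carbon, here on a sulfonyl sulfur whose other neighbours are a saturated chain carbon. Resting on the flat step a 1.0-fold higher number from compound 1 to compound 2 (0.01 log units; within the scatter), the step to compound 4 is expected to be a 1.0-fold higher number from compound 3 to compound 4 (0.01 log units; within the scatter). Compound 4 is therefore estimated at 25000 nM, expected between 10000 nM and 60000 nM.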

Compound 4, half-maximal inhibitory concentration: 27700 nM
Estimate against measurement, compound 4: 1.1-fold (0.04 log units) below; low and high end bracket the measured number.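

In this assay, 2-(trifluoromethyl)phenyl in place of 3-(trifluoromethyl)phenyl on a sulfonyl sulfur gives a 1.1-fold higher number from compound 3 to compound 4 (0.05 log units; within the scatter). Set beside the same change on a sulfur, the two steps do not differ: the same change on two cores in this assay, a 1.0-fold higher number (0.01 log units; within the scatter) from compound 1 to compound 2 and a 1.1-fold higher number (0.05 log units; within the scatter) from compound 3 to compound 4, 1.1-fold (0.04 log units) apart, within the scatter of two such steps Within this series, the change therefore carries from the core of compound 1 to the core of compound 3 with no step beyond the scatter, but this rests on two pairs in one assay and does not show that the change would stay flat on any other core or in any other read-out.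

The compounds shown leave open whether the same flat result holds when a nitrile or a chlorine stands in place of the trifluoromethyl on the phenyl ring. Also open, from the compounds shown here alone, is what a sulfoxide in place of the sulfur or sulfonyl, or an amine in place of the hydroxyl, would do to the numbers on either core.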